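Bromo to Cyano on the Sulfonyl Aryl Ring

The compounds below may be only part of what the source reports. "The series", "measured", "known", "first", "only" and "open" are said of these compounds alone.

Measured so far:
Compound 1, `CC1=NC(c2cn(S(=O)(=O)c3cccs3)c3ccc(C)cc23)CN1`, gives 11000 nM in an assay on isolated protein for inhibition of kallikrein-7 (Homo sapiens), read by fluorescence, with stated times of 10 min and 30 min; on this read-out lower numbers stand for stronger inhibition and higher numbers for weaker inhibition.
Compound 2, `CC1=NC(c2cn(S(=O)(=O)c3ccccc3Br)c3ccc(C)cc23)CN1`, gives 390 nM in this assay.

For the measured compounds named here, of the two numbers measured, compound 2 holds the lower one, and its only neighbour lies far away: the single step, a 28-fold lower number from compound 1 to compound 2 (1.45 log units; beyond the scatter), puts 2-bromophenyl in place of thiophen-2-yl on the sulfonyl sulfur. That is the whole of what has been measured.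

Compound 3, `CC1=NC(c2cn(S(=O)(=O)c3ccccc3C#N)c3ccc(C)cc23)CN1`, keeps the shared core of compound 2 and differs from it only by cyano in place of bromo on an aromatic carbon. Going by the values given here, no measured step bears directly on this change. Among the compounds with values here, the one step known, a 28-fold lower number from compound 1 to compound 2 (1.45 log units; beyond the scatter), exchanged the entire ring on the sulfonyl sulfur rather than one group on a fixed ring, so it says little about trading bromo for cyano, and the expectation has to be broad. In this assay compound 3 is expected to give about 800 nM, somewhere between 150 nM and 4500 nM. This estimate amounts to a 2.1-fold higher number from compound 2 to compound 3 (0.31 log units; beyond the scatter), a modest move toward a higher number, with the range wide enough to allow a step in either direction.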

Compound 3, half-maximal inhibitory concentration: 6700 nM
Compound 3: middle estimate off by 8.4-fold (0.92 log units), on the low side; the whole stated range lies below it.
By their numbers in this assay, from the lowest: compound 2; then compounds 3 and 1 (each within the scatter of the next).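

For the compounds shown here, until now the only step had exchanged a whole ring, which could not separate the ring itself from the group it carries. In this assay, changing just one group on the same aromatic carbon, ortho to a large group, gives a 17-fold higher number from compound 2 to compound 3 (1.24 log units; beyond the scatter), so what sits at this single position weighs heavily on the read-out. Keeping a six-membered ring is also not enough on its own: 2-cyanophenyl in place of thiophen-2-yl gives a 1.6-fold lower number from compound 1 to compound 3 (0.22 log units; within the scatter), so among these three compounds, only the 2-bromophenyl ring of compound 2 stands apart, and nothing in the data shown explains why bromo and cyano differ so sharply here.

With only two groups at this carbon, the compounds shown leave open how others would read there, such as chloro, methyl, methoxy or an amine, and two points set no trend. Also open, going by these compounds, is whether bromo would hold the low number of compound 2 on a different carbon of the same ring.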